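The source may report more compounds than this note shows. Statements on the series, on what has been measured and on what is new or still open speak of the compounds shown alone.

Measured compounds:
compound 1, `COc1ccc2ncc(S(=O)(=O)c3cccc(C#N)c3)c(N3CCC(C)CC3)c2c1`: 90%
compound 2, `COc1ccc2ncc(S(=O)(=O)c3cc(F)cc(F)c3)c(N3CCC(C)CC3)c2c1`: 30%
compound 3, `Cc1ccc2ncc(S(=O)(=O)c3cccc(F)c3)c(N3CCC(C)CC3)c2c1`: 94%

In an assay on isolated protein for displacement of a labelled ligand from metabotropic glutamate receptor 5 (Homo sapiens), with a stated time of 60 min, tested at 1 uM (on this read-out higher numbers stand for more inhibition at the one concentration tested (going by the name of the read-out) and lower numbers for less inhibition), compound 3 gives the highest of the three numbers. Its nearest neighbour is compound 1, whose value lies within the scatter of that of compound 3, so no order can be drawn between the two; compound 2 lies well below. Within the data shown here, the only single-point step among the measured compounds is a number 60 percentage points lower from compound 1 to compound 2 (beyond the scatter), and it concerns the aryl group on the sulfonyl sulfur, not the part of the core that is changed here.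

Compound 4, `COc1ccc2ncc(S(=O)(=O)c3cccc(F)c3)c(N3CCC(C)CC3)c2c1`, has yet to be measured. It differs from compound 3 in this way: methoxy in place of methyl on an aromatic carbon. Among the measured compounds shown here, no measured pair isolates this exchange; compound 1 and compound 3, which carry methoxy and methyl at that position, differ in a second place as well, and their values in this assay sit within the scatter of each other. A step of no real size is therefore expected, a number 6 percentage points lower from compound 3 to compound 4 (within the scatter). Compound 4 is estimated at 88%, within 70% to 98%.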

Compound 4, a percentage reported as inhibition, at one concentration (the size of the read-out at that concentration, not a potency): 68%
The estimate for compound 4 lay 20 percentage points above the measured number, and the stated range ends above it.
By their numbers in this assay, from the lowest: compound 2; then compound 4; then compounds 1 and 3 (each within the scatter of the next).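

In this assay, methoxy in place of methyl on this aromatic carbon gives a number 26 percentage points lower from compound 3 to compound 4 (beyond the scatter) with the rest of the structure unchanged, so the exchange at this position is not neutral. With methoxy held in place, the aryl group on the sulfonyl sulfur still matters: hydrogen in place of fluoro gives a number 38 percentage points higher from compound 2 to compound 4 (beyond the scatter) and fluoro in place of cyano gives a number 22 percentage points lower from compound 1 to compound 4 (beyond the scatter) on the same core. The closeness of compound 1 and compound 3, which differ in two places, therefore does not show that methoxy and methyl are interchangeable.

As far as these compounds go, how a hydroxyl group or an ethoxy group would fare on this carbon remains open. Nothing available explains why the number falls with methoxy here.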